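A New Amide Group on a Level Series

A few compounds are considered here, and "the series" means these few. Any claim that something is new, unique, unknown or untested is made for them only; others in the source may bear on it.

In a functional assay on MDA-MB-231 cells (Homo sapiens) for inhibition, read by CellTiter-Glo, with a stated time of 72 h (on this read-out lower numbers stand for higher toxicity in this test and higher numbers for lower toxicity in this test), compound 1 `CC1=C(CC(=O)NCCN(C)C)c2cc(F)ccc2/C1=C\c1nc2ccccc2s1` gives 3630 nM, compound 2 `CC1=C(CC(=O)N(C)CCN(C)C)c2cc(F)ccc2/C1=C\c1nc2ccccc2s1` gives 3800 nM, and compound 3 `CC1=C(CC(=O)NCCN2CCCC2)c2cc(F)ccc2/C1=C\c1nc2ccccc2s1` gives 3560 nM. Compound 3 thus stands within the scatter of both other compounds, and the three form one level.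

Compound 4 `CC1=C(CC(=O)N2CCN(c3ccncc3)CC2)c2cc(F)ccc2/C1=C\c1nc2ccccc2s1` carries 4-(pyridin-4-yl)piperazin-1-yl in place of (2-(pyrrolidin-1-yl)ethyl)amino on a carbonyl carbon.

Among the measured compounds shown here, three measured steps bear on this change. Methyl in place of hydrogen on the amide-type nitrogen gave a 1.0-fold higher number from compound 1 to compound 2 (0.02 log units; within the scatter), pyrrolidin-1-yl in place of dimethylamino gave a 1.0-fold lower number from compound 1 to compound 3 (0.01 log units; within the scatter), and exchanging the whole group on the carbonyl carbon gave a 1.1-fold lower number from compound 2 to compound 3 (0.03 log units; within the scatter). For the measured compounds named here, all three are small, yet no measured compound carries the entering group, so they offer only limited guidance here. No shift beyond the scatter is therefore expected, although the range is kept wide.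

The expected step is a 1.2-fold lower number from compound 3 to compound 4 (0.07 log units; within the scatter). For compound 4, the estimated value is 3000 nM, with an expected range of 1000 nM to 9000 nM.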

Compound 4, half-maximal cytotoxic concentration: 7710 nM
Compound 4: the middle estimate sits 2.6-fold (0.41 log units) below what was measured, and the stated range covers the measured number.
By their numbers in this assay, from the lowest: compounds 3, 1 and 2 (each within the scatter of the next); then compound 4.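

In this assay, the place on the carbonyl carbon proves not to be indifferent: 4-(pyridin-4-yl)piperazin-1-yl gives a 2.2-fold higher number from compound 3 to compound 4 (0.34 log units; beyond the scatter), and the same kind of exchange gives a 2.0-fold higher number from compound 2 to compound 4 (0.31 log units; beyond the scatter) and a 2.1-fold higher number from compound 1 to compound 4 (0.33 log units; beyond the scatter), a modest step against all three earlier groups alike. Compound 2 also lacks the amide hydrogen yet stays level with compound 1, so losing that hydrogen does not by itself go with the higher number. Nothing measured here gives a reason for the step.

The compounds shown leave open whether the piperazine ring or the pyridin-4-yl group goes with the step, a question that a 4-methylpiperazin-1-yl or 4-phenylpiperazin-1-yl group on the same carbonyl carbon would address. They also leave open whether a morpholin-4-yl group would stay level with compound 3 or move as compound 4 does.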